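The source may report more compounds than this note shows. Statements on the series, on what has been measured and on what is new or still open speak of the compounds shown alone.

For the measured compounds named here, compound 3 `CC(C)Oc1cc(-c2cncc(-c3c[nH]nc3C3CC3)c2)ccc1C(N)=O` gives 130 nM in an assay on cells for inhibition of MAP kinase-interacting serine/threonine-protein kinase 1 (Homo sapiens), read by mobility shift assay, with stated times of 10 min and 60 min, in the presence of a further agent that is not named here (on this read-out higher numbers stand for weaker inhibition and lower numbers for stronger inhibition), the second highest of the three numbers measured so far. Compound 1 `CC(C)Oc1cc(-c2cncc(-c3cnn(C4COC4)c3)c2)ccc1C(N)=O` gives 200 nM; compound 2 `Cc1n[nH]c(C)c1-c1cncc(-c2ccc(C(N)=O)c(OC(C)C)c2)c1` gives 33 nM. Compound 4 `CC(C)Oc1cc(-c2cncc(-c3nn[nH]n3)c2)ccc1C(N)=O` differs from compound 3 by 2H-tetrazol-5-yl in place of 3-cyclopropyl-1H-pyrazol-4-yl on an aromatic carbon. Going by the values given here, no measured step replaces this five-membered ring by a different ring; the nearest comparisons are a 1.5-fold lower number from compound 1 to compound 3 (0.19 log units; within the scatter) and a 3.9-fold higher number from compound 2 to compound 3 (0.60 log units; beyond the scatter), with a 6.1-fold lower number from compound 1 to compound 2 (0.78 log units; beyond the scatter) showing the widest spread seen for changes at this position, all modest. A small to modest step in this assay is therefore expected, more likely toward a higher number, and the estimated step is a 2.3-fold higher number from compound 3 to compound 4 (0.36 log units; beyond the scatter). Compound 4 is expected at about 300 nM, within a range from 80 nM to 1200 nM.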

Compound 4, half-maximal inhibitory concentration: 310 nM
The estimate for compound 4 lay 1.0-fold (0.01 log units) below the measured number; low and high end bracket the measured number.
By their numbers in this assay, from the lowest: compound 2; then compounds 3, 1 and 4 (each within the scatter of the next, the first and the last beyond it).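

In this assay, a five-membered aromatic ring with 4 hetero atoms and no further substituent is accepted at this position about as well as the 1-(oxetan-3-yl)-1H-pyrazol-4-yl group, with a 1.6-fold higher number from compound 1 to compound 4 (0.19 log units; within the scatter). Against the other two groups the change loses ground: a 2.4-fold higher number from compound 3 to compound 4 (0.38 log units; beyond the scatter) for the 3-cyclopropyl-1H-pyrazol-4-yl group and a 9.4-fold higher number from compound 2 to compound 4 (0.97 log units; beyond the scatter) for the 3,5-dimethyl-1H-pyrazol-4-yl group, the widest step yet at this position.

No measurement here accounts for these steps. Open, going by these compounds, is how a carboxylic acid or an aminomethyl group in place of the ring would read in this assay.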